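Swapping Aryl Halogen Groups in a Growth Inhibition Series

The source may hold more compounds than are shown below. What is called first, only, known or untested is meant among the compounds shown, and "the series" means these compounds.

Compound 2, `Cc1oc2c([C@H]3CCN(C)C[C@H]3O)c(O)cc(O)c2c(=O)c1C(O)c1cccc(Cl)c1`, was tested in a functional assay on HL-60 cells (Homo sapiens) for inhibition, read by MTT assay, with a stated time of 48 h, tested at 10 uM (a lower number here means less inhibition of growth, a higher number more inhibition of growth at the concentration tested), where compound 2 gives 22%. Compound 1, `Cc1cc(=O)c2c(O)c(CN(C)CC(=O)O)c(O)c([C@H]3CCN(C)C[C@H]3O)c2o1`, gives 23% in this assay. Of the two numbers available, compound 2 shows the lower one, but its gap to compound 1 lies within the usual scatter, so neither compound can be called more or less active than the other.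

Compound 3, `Cc1oc2c([C@H]3CCN(C)C[C@H]3O)c(O)cc(O)c2c(=O)c1C(O)c1ccc(F)cc1`, has not yet been measured. Its structure differs from compound 2 in one place: 4-fluorophenyl in place of 3-chlorophenyl on a saturated chain carbon bound to an aromatic carbon and an oxygen on a saturated carbon. Within the data shown here, no pair of measured compounds differs in a single place, and nothing measured so far bears on a change of this kind. With both measured compounds sitting close together and no guide on the change itself, the expected step is no change at the digits printed from compound 2 to compound 3 (within the scatter), meaning none beyond the scatter in either direction. Compound 3 is therefore estimated to give 22% in this assay, with a range from 8% to 38%.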

Compound 3, percent growth inhibition at one concentration: 30%
Compound 3: middle estimate off by 8 percentage points, on the low side, and the stated range covers the measured number.
By their numbers in this assay, from the lowest: compounds 2, 1 and 3 (each within the scatter of the next).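

In this assay, 4-fluorophenyl in place of 3-chlorophenyl on a saturated chain carbon bound to an aromatic carbon and an oxygen on a saturated carbon gives a number 8 percentage points higher from compound 2 to compound 3 (within the scatter). This is the first comparison shown that differs in one place, and it shows that this exchange of one halogen-bearing phenyl group for another leaves growth inhibition at the tested concentration within the scatter. Among these compounds, no supporting evidence accompanies the result, so it offers no account of the step.

The pair changes both the halogen and its place on the phenyl ring, so the two changes cannot be told apart. Going by these compounds, what an unsubstituted phenyl, a methoxyphenyl or an amine-bearing chain would give at this carbon also remains open.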